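Swapping an amino group for a methoxyphenyl ring

A few compounds are considered here, and "the series" means these few. Any claim that something is new, unique, unknown or untested is made for them only; others in the source may bear on it.

For the measured compounds named here, compound 2 `CC1CCN(C2CCN(S(=O)(=O)c3cccc(N)c3)CC2)CC1` gives 3400 nM in a functional assay on DLD-1 cells (Homo sapiens) for antiproliferative activity, read by CellTiter-Glo, with a stated time of 72 h (on this read-out higher numbers stand for weaker inhibition and lower numbers for stronger inhibition), the only number in this small set. Compound 1 `CC1CCN(C2CCN(S(=O)(=O)c3cccc(C(F)(F)F)c3)CC2)CC1` gives only > 5000 nM in this assay, which is a limit of the assay rather than a number. Going by the values given here, the step of an at least 1.4-fold lower number from compound 1 to compound 2 (0.16 log units; that floor lies within the scatter) is the sole measured comparison, and it was too small to stand out. Compound 3 `COc1ccccc1-c1cccc(S(=O)(=O)N2CCC(N3CCC(C)CC3)CC2)c1` carries 2-methoxyphenyl in place of amino on an aromatic carbon. Among the compounds with values here, no measured step exchanges an amino group for an aromatic ring, so neither direction nor size of this change can be read from the data. Compound 3 is therefore expected to sit close to its parent, an estimated step of a 1.4-fold lower number from compound 2 to compound 3 (0.13 log units; within the scatter). The estimate for compound 3 is 2500 nM, with a range from 600 nM to 10000 nM.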

Compound 3, half-maximal inhibitory concentration: 21 nM
Estimate against measurement, compound 3: 120-fold (2.08 log units) above, and the stated range ends above it.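

Of the groups shown at this position on the aromatic ring, only 2-methoxyphenyl brings a large change: in its place of amino, it gives a 160-fold lower number from compound 2 to compound 3 (2.21 log units; beyond the scatter). In place of trifluoromethyl, the same group gives an at least 230-fold lower number from compound 1 to compound 3 (2.37 log units; beyond the scatter). That second step is only a floor, because compound 1 stands at a limit and not at a number: the limit of > 5000 nM in this assay, at which 1 of the 3 values shown sits.

As far as these compounds go, whether the added ring or its methoxy group carries the gain stays open; a plain phenyl ring or a pyridine ring at this position would help separate the two.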